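This account rests on a few compounds, and the source may have more. Where it says the series, first, only, none or still open, it means among the compounds named here.

Measured in a functional assay on HeLa cells (Homo sapiens) for inhibition, read by MTT assay, with a stated time of 72 h; a higher number here means a weaker inhibitor, a lower number a stronger inhibitor:
Compound 1 `Cc1cccc(NC(=O)Nc2ccc(Oc3ncnc4[nH]ncc34)cc2)c1C`: > 10000 nM
Compound 2 `COc1cccc(NC(=O)Nc2ccc(Oc3ncnc4c3cnn4C)cc2)c1`: > 10000 nM
Compound 3 `O=C(Nc1ccc(Oc2ncnc3[nH]ncc23)cc1)Nc1cccnc1`: > 10000 nM

Each of these entries is a limit of the assay and not a number. The three compounds share one reading, (the limit of > 10000 nM in this assay, at which 3 of the 3 values shown sit). Compound 3 therefore has no exact position on the scale.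

Compound 4 `O=C(Nc1ccc(Oc2ncnc3[nH]ncc23)cc1)Nc1cccc(F)c1` has not yet been measured. It carries 3-fluorophenyl in place of pyridin-3-yl on an amide-type nitrogen.

Among the compounds with values here, only one measured step changes the group at this place: a step that the two limits leave unreadable from compound 1 to compound 3. That step runs between two limits. It gives no size to carry over. Compound 1, whose group here has a ring of carbon only, also reaches just a limit, > 10000 nM. Compound 4 likewise has a ring of carbon only here, so the measured compounds give no reason to expect a clear gain or loss in this assay.

The expected step, a number no higher from compound 3 to compound 4 (the limit leaves the size open), is therefore estimated with no firm direction. A further limit is the most likely report for compound 4. If a number appears, the estimate for compound 4 is 10000 nM, with an expected range from 3000 nM to 20000 nM.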

Compound 4, half-maximal inhibitory concentration: > 10000 nM
Compound 4: no number, only a limit (the forecaster's own chance of this, stated with the estimate: 70%); the middle value lies on the limit itself.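

In this assay compound 4 gives > 10000 nM, which is a limit of the assay and not a number. The steps to compound 4 from compound 3 and from compound 1 therefore cannot be read, as all the entries are limits: the limit of > 10000 nM in this assay, at which 4 of the 4 values shown sit.

From the compounds shown here alone, whether changing the group on the amide-type nitrogen alters inhibition in this assay at all remains open.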